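Swapping a fluorophenyl for a pyridyl on a chalcone scaffold

This account rests on a few compounds, and the source may have more. Where it says the series, first, only, none or still open, it means among the compounds named here.

The measured compounds and their readings in an ADME assay on Vero cells (Chlorocebus sabaeus) for cytotoxicity, read by MTT assay; on this read-out lower numbers stand for stronger inhibition and higher numbers for weaker inhibition:
- compound 1 `C=CCOc1cc(OC)c(C(=O)/C=C/c2cc(OC)c(OC)c(OC)c2)c(OCC=C)c1`: 40900 nM
- compound 2 `C=CCOc1cc(OC)c(C(=O)/C=C/c2ccccc2F)c(OCC=C)c1`: 16300 nM
- compound 3 `C=CCOc1cc(OC)c(C(=O)/C=C/c2cccc(OC)c2)c(OCC=C)c1`: 142000 nM

Compound 2 gives the lowest number of the three in this assay: compound 1 sits closest to it, and compound 3 furthest, as shown by an 8.7-fold higher number from compound 2 to compound 3 (0.94 log units; beyond the scatter). The unmeasured compound 4 `C=CCOc1cc(OC)c(C(=O)/C=C/c2ccccn2)c(OCC=C)c1` differs from compound 2 in one place: pyridin-2-yl in place of 2-fluorophenyl on a double-bonded chain carbon bound to a double-bonded chain carbon. Among the measured compounds shown here, no measured step covers exactly this replacement. For the measured compounds named here, the only step that bears on it is the one in which the 2-fluorophenyl of compound 2 was exchanged, an 8.7-fold higher number from compound 2 to compound 3 (0.94 log units; beyond the scatter), and that exchange raised the number. Compound 1, which also lacks the 2-fluorophenyl, shows a number above compound 2 as well. A change at the same place is therefore expected to move compound 4 upward by a modest amount, a 2.0-fold higher number from compound 2 to compound 4 (0.29 log units; within the scatter), though the scatter leaves room for no change. Compound 4 is estimated at 32000 nM in this assay, with a range from 11000 nM to 95000 nM.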

Compound 4, half-maximal inhibitory concentration: 2800 nM
Compound 4: the middle estimate sits 11-fold (1.06 log units) above what was measured; measured number below the stated range.
By their numbers in this assay, from the lowest: compound 4; then compound 2; then compound 1; then compound 3.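

In this assay, among the compounds shown here, the group at this place can lower the number as well as raise it: pyridin-2-yl in place of 2-fluorophenyl gives a 5.8-fold lower number from compound 2 to compound 4 (0.77 log units; beyond the scatter), whereas the only earlier step here, to 3-methoxyphenyl, went upward. Set against 3-methoxyphenyl, the same group gives a 51-fold lower number from compound 3 to compound 4 (1.71 log units; beyond the scatter), so this one position spans a wider range than the earlier compounds showed, and 2-fluorophenyl no longer marks its low end. Nothing at hand explains why the number fell.

The compounds shown leave open how an unsubstituted phenyl or a pyrimidinyl ring would read at this place. That leaves unsettled whether the fall follows the ring nitrogen that enters or the fluorine that leaves.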